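Swapping trifluoromethoxy for chloro in a cytotoxicity assay

A few compounds are considered here, and "the series" means these few. Any claim that something is new, unique, unknown or untested is made for them only; others in the source may bear on it.

Compound 1 `C=C[C@@](C)(/C=C/c1ccc(O)c(/C=C/C(=O)c2ccccc2)c1)CCC=C(C)C`: > 20000 nM (a limit)
Compound 2 `COc1ccc(/C=C/[C@@](C)(/C=C/c2ccc(O)c(/C=C/C(=O)OCc3ccccc3)c2)CCC=C(C)C)cc1`: > 36600 nM (a limit)
Compound 3 `C=C[C@@](C)(/C=C/c1ccc(Nc2ccc(OC(F)(F)F)cc2)cc1)CCC=C(C)C`: > 36600 nM (a limit)

All three compounds were tested in an ADME assay on BJ cells (Homo sapiens) for cytotoxicity, with a stated time of 72 h (a lower number here means that less compound is needed, a higher number that more compound is needed for the effect), and none of them gave a number, only a limit. Compound 3 is one of the two compounds at the higher of the two limits, with > 36600 nM as its limit.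

Compound 4 `C=C[C@@](C)(/C=C/c1ccc(Nc2ccc(Cl)cc2)cc1)CCC=C(C)C` differs from compound 3 in one place, with chloro in place of trifluoromethoxy on an aromatic carbon, para to a large group: chloro in place of trifluoromethoxy on an aromatic carbon. Within the data shown here, no measured pair of compounds shows what a change of this kind does in this assay. Among the measured compounds shown here, the only guide is compound 3 itself, so no step beyond the scatter is expected, in either direction. The expected move is a number no higher from compound 3 to compound 4 (the limit leaves the size open). Compound 4 may well also be reported only as a limit. For compound 4 the estimated value is 36600 nM, with an expected range from 15000 nM to 70000 nM.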

Compound 4, half-maximal effective concentration: > 36600 nM
Compound 4: no number, only a limit (the forecaster's own chance of this, stated with the estimate: 75%); the middle value lies on the limit itself.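

Compound 3 and compound 4 each give only a limit, and no step can be read between them for chloro in place of trifluoromethoxy. The compounds shown leave open where their actual values lie and whether this change moves the value at all.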